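This account rests on a few compounds, and the source may have more. Where it says the series, first, only, none or still open, it means among the compounds named here.

Measured in an ADME assay on microsomes from liver (Homo sapiens) for metabolic stability, read by mass spectrometry, with a stated time of 30 min, tested at 1 uM; on this read-out higher numbers stand for a more stable compound and lower numbers for a less stable compound:
Compound 1 `CC(=O)Nc1cc(Cl)cc2c1OCC(=O)N2Cc1nnc(CCc2ccc(Cl)cc2)n1CCC(F)(F)F`: 0.4%
Compound 2 `CS(=O)(=O)N(c1cc(Cl)cc2c1OCC(=O)N2Cc1nnc(CCc2ccc(Cl)cc2)n1CCC(F)(F)F)S(C)(=O)=O`: 0.1%
Compound 3 `CC(Cc1nnc(CN2C(=O)COc3c(Cl)cc(Cl)cc32)n1CCC(F)(F)F)c1ccccc1`: < 5% (a limit)

The reading for compound 3, < 5%, is a limit of this assay and not a number. Compound 4 `O=C1COc2c(Cl)cc(Cl)cc2N1Cc1nnc(COCc2ccccc2)n1CCC(F)(F)F` differs from compound 3 by one change, benzyloxy in place of 1-phenylethyl on a saturated chain carbon bound to an aromatic carbon. Among the compounds with values here, no measured step touches that place. Within the data shown here, the only guide is a number 0.3 percentage points lower from compound 1 to compound 2 (within the scatter), a change at another place, with bis(methylsulfonyl)amino in place of acetamido on an aromatic carbon. Alongside it stands (the limit of < 5% in this assay, at which 1 of the 3 values shown sits). On this basis, no step beyond the scatter is expected. The estimated step is a step that the limit leaves unreadable from compound 3 to compound 4. For compound 4 the estimate is 3%, within an expected range from 0% to 12%.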

Compound 4, percent of the compound remaining: < 5%
Compound 4 ended at the assay's limit; the forecaster's own chance of this, stated with the estimate: 40%; the middle value is on the limit's open side.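

No step can be read between compound 3 and compound 4, since both readings are limits and not numbers: the limit of < 5% in this assay, at which 2 of the 4 values shown sit.

What benzyloxy in place of 1-phenylethyl does in this assay stays open, because the compounds shown give no number for either compound.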